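A few compounds are considered here, and "the series" means these few. Any claim that something is new, unique, unknown or untested is made for them only; others in the source may bear on it.

In a functional assay on HCT-116 cells (Homo sapiens) for antiproliferative activity, read by MTT assay, with a stated time of 24 h (on this read-out higher numbers stand for weaker inhibition and lower numbers for stronger inhibition), two compounds sharing one core have been measured so far. Compound 1 `COc1cc(OC)c(-c2coc3cc(OCC=C(C)C)ccc3c2=O)cc1OC` gives 680 nM, and compound 2 `COc1cc(OC)c(-c2coc3cc(OCc4ccc(F)cc4)ccc3c2=O)cc1OC` gives 950 nM. Among the measured compounds shown here, compound 2 therefore holds the higher of only two numbers, but it cannot be told apart from compound 1, as the gap is within the scatter.

The next structure is compound 3 `COc1cc(OC)c(-c2coc3cc(OCc4ccc(Br)cc4)ccc3c2=O)cc1OC`, with bromo in place of fluoro on an aromatic carbon, para to a large group: bromo in place of fluoro on an aromatic carbon. For the measured compounds named here, no measured step exchanges these two atoms, so direct evidence is lacking. The nearest guide is the exchange of the whole 4-fluorophenyl group, which gave a 1.4-fold higher number from compound 1 to compound 2 (0.15 log units; within the scatter). A smaller edit at that end is therefore not expected to move the number beyond the scatter, in either direction. The expected change is a 1.1-fold lower number from compound 2 to compound 3 (0.02 log units; within the scatter). Compound 3 is estimated at 900 nM, with an expected range from 400 nM to 2000 nM.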

Compound 3, half-maximal inhibitory concentration: 1980 nM
Compound 3: middle estimate off by 2.2-fold (0.34 log units), on the low side, within the range that was stated.
By their numbers in this assay, from the lowest: compounds 1 and 2 (each within the scatter of the next); then compound 3.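

Changing one atom at the far end of the side group is enough to register in this assay: bromo in place of fluoro gives a 2.1-fold higher number from compound 2 to compound 3 (0.32 log units; beyond the scatter) and so lies beyond the scatter, a modest step but a real one. The exchange of the whole end group also separates once bromo is present, with a 2.9-fold higher number from compound 1 to compound 3 (0.46 log units; beyond the scatter) in this assay, which makes compound 3 the weakest of the three. The data at hand give no explanation for the rise with bromo.

On these data alone, it remains open whether the number depends on the choice of halogen alone, since chloro or iodo at this same place would fill. A plain unsubstituted benzyl, a methoxy or an amine there would show whether any group at this place can bring the number down.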